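This account rests on a few compounds, and the source may have more. Where it says the series, first, only, none or still open, it means among the compounds named here.

Values measured in a functional assay on PC-3 cells (Homo sapiens) for cytotoxicity, read by MTT assay, with a stated time of 72 h (a higher number here means a weaker inhibitor, a lower number a stronger inhibitor), follow.
- compound 1 `O=C(/C=C/c1ccc([N+](=O)[O-])cc1)Nc1cc2c(Nc3ccc(F)c(Cl)c3)ncnc2cc1O[C@H]1CCOC1` gives 22800 nM
- compound 2 `O=C(/C=C/c1ccccc1[N+](=O)[O-])Nc1cc2c(Nc3ccc(F)c(Cl)c3)ncnc2cc1O[C@H]1CCOC1` gives 7760 nM
- compound 3 `O=C(/C=C/c1ccc(F)cc1Cl)Nc1cc2c(Nc3ccc(F)c(Cl)c3)ncnc2cc1O[C@H]1CCOC1` gives 7150 nM

Compound 3 stands level with compound 2 (a 1.1-fold lower number from compound 2 to compound 3 (0.04 log units; within the scatter)) and clear of compound 1 (a 3.2-fold lower number from compound 1 to compound 3 (0.50 log units; beyond the scatter)). Compound 4 `COc1ccc(/C=C/C(=O)Nc2cc3c(Nc4ccc(F)c(Cl)c4)ncnc3cc2O[C@H]2CCOC2)cc1` differs from compound 3 in one place (4-methoxyphenyl in place of 2-chloro-4-fluorophenyl on a double-bonded chain carbon bound to a double-bonded chain carbon), with 4-methoxyphenyl in place of 2-chloro-4-fluorophenyl. Among the measured compounds shown here, no measured step makes this exchange. For the measured compounds named here, the steps that bear on it are aryl swaps at the same place, and they are small. One is modest (a 2.9-fold lower number from compound 1 to compound 2 (0.47 log units; beyond the scatter)). The other lies within the scatter (a 1.1-fold lower number from compound 2 to compound 3 (0.04 log units; within the scatter)). The expected step in this assay is therefore small, probably none beyond the scatter (a 1.5-fold higher number from compound 3 to compound 4 (0.19 log units; within the scatter)). The estimated value for compound 4 is 11000 nM (expected range 5000 nM to 25000 nM).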

Compound 4, half-maximal inhibitory concentration: 2240 nM
For compound 4 the middle estimate is 4.9-fold (0.69 log units) above the measured one; the whole stated range lies above it.
By their numbers in this assay, from the lowest: compound 4; then compounds 3 and 2 (each within the scatter of the next); then compound 1.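

In this assay the change to 4-methoxyphenyl on a double-bonded chain carbon brings a 3.2-fold lower number from compound 3 to compound 4 (0.50 log units; beyond the scatter) and a 3.5-fold lower number from compound 2 to compound 4 (0.54 log units; beyond the scatter) and so separates compound 4 from two compounds that stood level. Methoxy in place of nitro on an aromatic carbon brings a 10-fold lower number from compound 1 to compound 4 (1.01 log units; beyond the scatter), the only large step here, showing that the aryl group at this place can shift the number further than the earlier swaps did. Nothing measured here accounts for these steps.

From the compounds shown here alone, whether the lower number belongs to methoxy itself remains open. A 4-ethoxyphenyl or 4-aminophenyl group would bear on that.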